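Bromo on the benzylamide of the weakest compound

The compounds below may be only part of what the source reports. "The series", "measured", "known", "first", "only" and "open" are said of these compounds alone.

Measured in a functional assay on BMMC cells (Mus musculus, strain C57BL/6) for inhibition, with stated times of 5 days and 48 h; a higher number here means a weaker inhibitor, a lower number a stronger inhibitor:
- compound 1 `C=C1CC[C@@H]2[C@](C)(CNCc3ccc(Cl)cc3)[C@H](O)CC[C@@]2(C)[C@@H]1/C=C/C1=CCOC1=O`: 420 nM
- compound 2 `C=C1CC[C@@H]2[C@](C)(CNCc3nccs3)[C@H](O)CC[C@@]2(C)[C@@H]1/C=C/C1=CCOC1=O`: 700 nM
- compound 3 `C=C1CC[C@H]2[C@@](C)(CC[C@@H](O)[C@@]2(C)C(=O)NCc2ccccc2)[C@@H]1/C=C/C1=CCOC1=O`: 19400 nM

Compound 3 gives the highest number of the three and is the weakest inhibitor of the set: a 46-fold higher number from compound 1 to compound 3 (1.66 log units; beyond the scatter) and a 28-fold higher number from compound 2 to compound 3 (1.44 log units; beyond the scatter) both lie beyond the scatter, and both exchange the amine-linked arm for the benzylcarbamoyl arm. Compound 4 `C=C1CC[C@H]2[C@@](C)(CC[C@@H](O)[C@@]2(C)C(=O)NCc2ccc(Br)cc2)[C@@H]1/C=C/C1=CCOC1=O` keeps that arm and differs from compound 3 by bromo in place of hydrogen on an aromatic carbon.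

Among the compounds with values here, no measured step changes a substituent on this ring while the amide link is kept, so none bears on it directly. Within the data shown here, the only step confined to the pendant ring, a 1.7-fold higher number from compound 1 to compound 2 (0.22 log units; within the scatter), exchanges the whole ring and stays within the scatter; the two large steps concern the link to the core, not the ring. The change from compound 3 to compound 4 is therefore expected to give no step beyond the scatter, with at most a slight drift to a lower number, a 1.5-fold lower number from compound 3 to compound 4 (0.17 log units; within the scatter). Compound 4 is estimated at 13000 nM, within 5000 nM to 32000 nM.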

Compound 4, half-maximal inhibitory concentration: 3450 nM
The estimate for compound 4 lay 3.8-fold (0.58 log units) above the measured number; measured number below the stated range.
By their numbers in this assay, from the lowest: compounds 1 and 2 (each within the scatter of the next); then compound 4; then compound 3.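

In this assay, within the data shown here, the pendant ring of the benzylcarbamoyl arm responds to a single substituent: a 5.6-fold lower number from compound 3 to compound 4 (0.75 log units; beyond the scatter) is the only step that changes this ring with the amide link kept. Bromo at this position narrows the gap to the amine-linked arm without closing it, as an 8.2-fold higher number from compound 1 to compound 4 (0.91 log units; beyond the scatter) and a 4.9-fold higher number from compound 2 to compound 4 (0.69 log units; beyond the scatter) both remain beyond the scatter, though they are modest where the steps from these compounds to compound 3 were large. Nothing in hand gives a reason for the step from hydrogen to bromo.

From the compounds shown here alone, whether this step is specific to bromo remains open; fluoro or methoxy at the same place on the benzylamide of compound 3 would test that. Also open, going by these compounds, is whether bromo in place of the chloro of compound 1 would shift the number on the amine-linked arm.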